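Working notes on three measured compounds and one to come

This account rests on a few compounds, and the source may have more. Where it says the series, first, only, none or still open, it means among the compounds named here.

Values in an assay on CHO cells for displacement of a labelled ligand from adenosine receptor A3 (Homo sapiens), read by scintillation counting, with a stated time of 3 h; a higher number here means a weaker inhibitor, a lower number a stronger inhibitor:
compound 1 `Cn1c(-c2ccc(O)cc2)nc2c(NC3CCCC3)ncnc21`: 521 nM
compound 2 `CCn1c(-c2ccccc2)nc2c(NC3CCCC3)ncnc21`: 354 nM
compound 3 `CCCn1c(-c2ccccc2)nc2c(N)ncnc21`: 9280 nM

Compound 1 holds the second highest number of the three. Compound 2 lies nearest, within the usual scatter, so no order between compound 1 and compound 2 can be read. Compound 3 lies furthest, with a number beyond the scatter above compound 1.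

Compound 4 `Cn1c(-c2ccc(F)cc2)nc2c(NC3CCCC3)ncnc21` differs from compound 1 by fluoro in place of hydroxy on an aromatic carbon. Among the compounds with values here, no measured pair shows this change. Compound 2, which carries no group on that ring, sits within the scatter of compound 1, so in this assay a step from compound 1 to compound 4 of no more than the scatter is expected, in either direction.

Compound 4 is estimated at 420 nM, between 150 nM and 1200 nM, an expected step of a 1.2-fold lower number from compound 1 to compound 4 (0.09 log units; within the scatter).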

Compound 4, inhibition constant: 1140 nM
Estimate against measurement, compound 4: 2.7-fold (0.43 log units) below, within the range that was stated.
By their numbers in this assay, from the lowest: compounds 2 and 1 (each within the scatter of the next); then compound 4; then compound 3.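

Within the data shown here, this is the first comparison that differs in one place only: in this assay, fluoro in place of hydroxy gives a 2.2-fold higher number from compound 1 to compound 4 (0.34 log units; beyond the scatter) and so is a modest step, not a silent swap. The group para to a large group can therefore move the number, with 4-fluorophenyl on the weaker side of 4-hydroxyphenyl. Nothing measured here accounts for the step.

The compounds shown leave open how a methoxy, chloro or amine group would read at this place, and so whether the step follows the loss of hydroxy or the arrival of fluoro.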